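The compounds below may be only part of what the source reports. "The series", "measured", "known", "first", "only" and "open" are said of these compounds alone.

Measured compounds:
compound 1 `CN1CCN(c2ccc3[nH]nc(S(=O)(=O)c4ccc(Cl)cc4)c3c2)CC1`: 100%
compound 2 `CN1CCN(c2cccc3c(S(=O)(=O)c4cccc5ccccc45)n[nH]c23)CC1`: 100%
compound 3 `CC(C)Cn1nc(S(=O)(=O)c2cccc3ccccc23)c2cc(N3CCN(C)CC3)ccc21`: 100%

In a functional assay on HeLa cells for antagonist activity at 5-hydroxytryptamine receptor 6 (Homo sapiens) (on this read-out lower numbers stand for smaller maximal responses and higher numbers for larger maximal responses), compound 1 gives 100%, and compound 2 and compound 3 give the same reading at the digits shown, so compound 1 stands level with both, and the differences among the three lie within the usual scatter. For the measured compounds named here, no step between measured compounds is available here.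

Compound 4 `CN1CCN(c2ccc3[nH]nc(S(=O)(=O)c4c(Cl)cccc4Cl)c3c2)CC1` has not been measured. It differs from compound 1 by 2,6-dichlorophenyl in place of 4-chlorophenyl on a sulfonyl sulfur. With all three measured compounds sitting at the same level in this assay, no step beyond the scatter is expected here, and the step from compound 1 to compound 4 is estimated as no change at the digits printed from compound 1 to compound 4 (within the scatter). Compound 4 is therefore expected to reach 100%, within a range from 88% to 106%.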

Compound 4, largest response reached (reported as Imax), in percent of the reference or control that the assay uses: 100%
Estimate against measurement, compound 4: no gap at the digits printed; the measured number falls inside the stated range.
By their numbers in this assay, from the lowest: compounds 1, 2, 3 and 4 (each within the scatter of the next).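

In this assay, for the compounds shown here, 2,6-dichlorophenyl in place of 4-chlorophenyl on a sulfonyl sulfur brings no change at the digits printed from compound 1 to compound 4 (within the scatter) and gives the only comparison here between compounds that differ in one place. It shows that, at this position, the maximal response holds when the aryl group carries a second chlorine and the chlorine pattern changes. No evidence available here bears on why the reading holds. Still open, on these data alone, is whether a phenyl group carrying an amine or a carboxylic acid on this sulfonyl sulfur would hold the reading as well.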